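From Ethyl to Pentyl on a Shared Core

The source may hold more compounds than are shown below. What is called first, only, known or untested is meant among the compounds shown, and "the series" means these compounds.

Three measured compounds share one core, and every value shown for them reaches only the limit of an assay on isolated protein for inhibition of Polyunsaturated fatty acid lipoxygenase ALOX15 (Homo sapiens), read by spectrophotometry, with a stated time of 10 min; on this read-out lower numbers stand for stronger inhibition and higher numbers for weaker inhibition. Compound 1 `Nc1sc(-c2ccccc2)cc1C(=O)NCCCCc1ccccc1` gives >= 50000 nM in this assay, a limit rather than a number. Compound 2 `CCCCN(CCCC)C(=O)c1cc(-c2ccccc2)sc1N` likewise gives >= 50000 nM in this assay, again a limit. Compound 3 `CCCCNC(=O)c1cc(CC)sc1N` gives >= 50000 nM in this assay, also a limit. Within the data shown here, compound 3 thus stands at the limit shared by every value shown, as the limit of >= 50000 nM in this assay, at which 3 of the 3 values shown sit, records, and no step between measured compounds exists to show how changes to the chain move the read-out. Compound 4 `CCCCCc1cc(C(=O)NCCCC)c(N)s1` differs from compound 3 by propyl in place of hydrogen on a saturated chain carbon, two bonds along the chain from an aromatic carbon, so that ethyl becomes pentyl. With every measured value at the limit, no step beyond the scatter is foreseeable in either direction. Compound 4 is expected to show a step of a number no higher from compound 3 to compound 4 (the limit leaves the size open), meaning no real movement. Compound 4 is estimated at 50000 nM, with a range from 15000 nM to 150000 nM.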

Compound 4, half-maximal inhibitory concentration: >= 50000 nM
Compound 4 ended at the assay's limit; the forecaster's own chance of this, stated with the estimate: 75%; the middle value sits exactly at the limit.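

Compound 3 and compound 4 both rest at a limit rather than a number, so no step can be read between them: the limit of >= 50000 nM in this assay, at which 4 of the 4 values shown sit.

The compounds shown leave open what any of their true values is, and whether ethyl or pentyl on the shared core makes any difference to inhibition.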